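Nitro substitution at a second aromatic position

The compounds below may be only part of what the source reports. "The series", "measured", "known", "first", "only" and "open" are said of these compounds alone.

Compound 1 `CSC1=NC2/C(=C(/O)OCCCCCSc3ccccc32)C(C)=N1` stands at the highest of the two numbers measured in an assay on Myocardium (Cavia porcellus) for displacement of a labelled ligand from Voltage-dependent L-type calcium channel subunit alpha-1C (Homo sapiens) (a higher number here means weaker binding, a lower number tighter binding), giving 18 nM. Compound 2 `CSC1=NC2/C(=C(/O)OCCCCCSc3c2cccc3[N+](=O)[O-])C(C)=N1` in this assay gives 5 nM. Compound 3 `CSC1=NC2/C(=C(/O)OCCCCCSc3ccc([N+](=O)[O-])cc32)C(C)=N1` carries the change (nitro in place of hydrogen on an aromatic carbon). Going by the values given here, the only measured step that bears on this change is a 3.6-fold lower number from compound 1 to compound 2 (0.56 log units; beyond the scatter), modest but beyond the scatter, and it too introduces a nitro group on the aromatic ring, though at a different position. A lowering of similar or somewhat smaller size is therefore expected for compound 3, a 2.0-fold lower number from compound 1 to compound 3 (0.30 log units; within the scatter). Compound 3 is estimated at 9 nM, within 3 nM to 30 nM.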

Compound 3, dissociation constant: 873 nM
Beside the measured number, compound 3's estimate is 97-fold (1.99 log units) below it; measured number outside the range, above it.
By their numbers in this assay, from the lowest: compound 2; then compound 1; then compound 3.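

In this assay, the same replacement of hydrogen by nitro gives a 49-fold higher number from compound 1 to compound 3 (1.69 log units; beyond the scatter) at this position, whereas the other nitro placement gives a 3.6-fold lower number from compound 1 to compound 2 (0.56 log units; beyond the scatter). The two steps run in opposite directions, so on this ring the outcome of adding nitro depends on where it sits, and a gain at one position does not carry over to another. Nothing available accounts for this reversal.
Going by these compounds, it remains open whether the rise in the number is specific to nitro at this position. An amine, a methoxy group or a fluorine atom there would help separate the position from the group.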